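Mirror-image pair in the antiproliferative series

The source may report more compounds than this note shows. Statements on the series, on what has been measured and on what is new or still open speak of the compounds shown alone.

Three compounds have numbers in a functional assay on MCF7 cells (Homo sapiens) for antiproliferative activity, read by sulforhodamine B assay, with a stated time of 48 h; a lower number here means a stronger inhibitor, a higher number a weaker inhibitor. Compound 1 `C[C@@]12CCCC[C@H]1CC=C(O)C2=O` gives 119000 nM in this assay. Compound 2 `CC1(C)[C@@H]2CC3=NCC(=O)O[C@@]3(C)[C@H]1C2` gives 22000 nM in this assay. Compound 3 `CC(C)(C)OC(=O)n1cnc(C[C@H]2N=C3C[C@H]4C[C@H](C4(C)C)[C@@]3(C)OC2=O)c1` gives 142000 nM in this assay. Compound 2 stands lowest of the three; the nearest number is that of compound 1, and the gap lies beyond the scatter, as does the larger gap to compound 3. Among the compounds with values here, no two measured compounds differ in a single place, so no measured step is available to set a scale.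

Compound 4 `CC1(C)[C@H]2CC3=NCC(=O)O[C@]3(C)[C@@H]1C2` is not yet measured. Relative to compound 2: the two compounds have the same atoms and bonds and differ only in configuration as drawn: 3 of 3 stereo elements differ (all stereocentres are inverted: mirror images); a stereocentre at a saturated ring carbon is drawn S in compound 2 and R in compound 4; a stereocentre at a saturated ring carbon is drawn S in compound 2 and R in compound 4; a stereocentre at a saturated ring carbon is drawn S in compound 2 and R in compound 4. Within the data shown here, nothing among the measured compounds shows how this assay answers to a mirror image, so the direction of the step is open. A number close to that of compound 2 or a weaker one both seem possible; a clearly stronger one seems less likely given that compound 2 already stands lowest at 22000 nM.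

Compound 4 is expected to give about 45000 nM in this assay, within a range of 12000 nM to 200000 nM. The expected step is a 2.0-fold higher number from compound 2 to compound 4 (0.31 log units; beyond the scatter), a modest weakening that may still fall within the scatter.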

Compound 4, half-maximal inhibitory concentration: > 300000 nM
Compound 4 ended at the assay's limit; the forecaster's own chance of this, stated with the estimate: 15%; middle value at least 6.6-fold (0.82 log units) away from the limit.
By their numbers in this assay, from the lowest: compound 2; then compounds 1 and 3 (each within the scatter of the next). At a limit, above all of these: compound 4.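

In this assay the series now has its first readable step: an at least 13-fold higher number from compound 2 to compound 4 (1.13 log units; beyond the scatter) and it counts as large. Compound 4 gives > 300000 nM as its entry, and this is a limit of the assay, not a number, so the step has a known minimum and no known size. Configuration alone therefore matters in this assay, with the whole of the change in the inversion of all three stereocentres and no group entering or leaving, as the pair shows: the fact that compounds 2 and 4 differ only in the configuration as drawn.

The compounds shown hold only the full mirror image, so the share of each single stereocentre in this step stays open, as does whether the mirror image of compound 3 would answer in the same way in this assay. Also open, as far as these compounds go, is what an amine or a carboxylic acid carried on the core of compound 2 would do to the number in this assay, and whether any such compound would keep the difference between the two mirror forms.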